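This account rests on a few compounds, and the source may have more. Where it says the series, first, only, none or still open, it means among the compounds named here.

Three compounds share one core and differ only in the group on the amide-type nitrogen. Compound 1 `COc1ccc(NC(=O)c2c(O)c3cccnc3n(-c3ccccc3)c2=O)cc1` carries a 4-methoxyphenyl there; in a functional assay on the whole organism for inhibition, with Rattus norvegicus as the target, read by cytopathic effect and paw edema, at a dose of 100 mg/kg by the oral route (on this read-out lower numbers stand for less inhibition and higher numbers for more inhibition at the one dose given (going by the name of the read-out)), compound 1 gives -1.9%. Compound 2 `O=C(Nc1cccc(Cl)c1)c1c(O)c2cccnc2n(-c2ccccc2)c1=O` carries a 3-chlorophenyl, and in this assay compound 2 gives 13.4%. Compound 3 `O=C(Nc1nccs1)c1c(O)c2cccnc2n(-c2ccccc2)c1=O` carries a 1,3-thiazol-2-yl, and in this assay compound 3 gives 2.5%. Among these three numbers compound 3 stands second highest: a number 4.4 percentage points higher from compound 1 to compound 3 (within the scatter), and a number 10.9 percentage points lower from compound 2 to compound 3 (beyond the scatter). Within the data shown here, the only step beyond the scatter is a number 15.3 percentage points higher from compound 1 to compound 2 (beyond the scatter).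

Compound 4 `COc1ccc(NC(=O)c2c(O)c3cccnc3n(-c3ccccc3)c2=O)cn1` is not yet measured. It differs from compound 3 in one place: 6-methoxypyridin-3-yl in place of 1,3-thiazol-2-yl on an amide-type nitrogen. The entering 6-methoxypyridin-3-yl is close in shape to the 4-methoxyphenyl of compound 1, so the step that bears most on it is a number 4.4 percentage points higher from compound 1 to compound 3 (within the scatter), which lies within the scatter. Nothing in the shown steps points to a change of the size seen in a number 15.3 percentage points higher from compound 1 to compound 2 (beyond the scatter). He therefore expects compound 4 to land near compound 1 and compound 3, with the step of a number 1.5 percentage points lower from compound 3 to compound 4 (within the scatter) expected to stay within the scatter. His estimate for compound 4 in this assay is 1%, with a range from -11% to 13%.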

Compound 4, a percentage reported as inhibition, in the whole organism at one dose (the size of the read-out at that dose, not a potency): -10.2%
For compound 4 the middle estimate is 11.2 percentage points above the measured one; measured number inside the range.
By their numbers in this assay, from the lowest: compounds 4, 1 and 3 (each within the scatter of the next, the first and the last beyond it); then compound 2.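

In this assay, among these compounds, the earlier compounds could not separate the 4-methoxyphenyl from the 1,3-thiazol-2-yl on this amide-type nitrogen, but the 6-methoxypyridin-3-yl does separate from the 1,3-thiazol-2-yl (a number 12.7 percentage points lower from compound 3 to compound 4 (beyond the scatter)), so the change of ring here can register beyond the scatter even among groups that stay low on this read-out. The exchange for the 3-chlorophenyl gives a wider separation (a number 23.6 percentage points lower from compound 2 to compound 4 (beyond the scatter)), which leaves compound 2 beyond the scatter of all three other compounds, whereas the exchange for the 4-methoxyphenyl cannot be told from scatter (a number 8.3 percentage points lower from compound 1 to compound 4 (within the scatter)), so the two methoxy-bearing aryl groups remain indistinguishable at this single dose. Compound 1 thus lies within the scatter of both compound 3 and compound 4 although those two lie beyond it from each other, and nothing shown gives a reason for any of these steps.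

The compounds shown leave open whether the chlorine of compound 2 matters by itself, which an unsubstituted phenyl or a 4-chlorophenyl on this nitrogen would test. They also leave open what a carboxylic acid or a morpholine on the aryl ring would do, and whether any change to the phenyl on the shared core would move these numbers.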